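A few compounds are considered here, and "the series" means these few. Any claim that something is new, unique, unknown or untested is made for them only; others in the source may bear on it.

Of the compounds shown here, three have been measured in an assay on cells for displacement of a labelled ligand from Ras guanyl-releasing protein 3 (Homo sapiens); a higher number here means a weaker inhibitor, a lower number a stronger inhibitor. Compound 1 `CN(C)c1ccc(C(=O)OCC2(CO)C/C(=C\c3cnc4ccccc4c3)C(=O)O2)cc1` gives 137 nM. Compound 2 `CN(C)c1ccc(C(=O)OCC2(CO)C/C(=C/c3ccncc3)C(=O)O2)cc1` gives 2360 nM, and compound 3 `CCCC(CCC)C(=O)OCC1(CO)C/C(=C/c2cccnc2)C(=O)O1` gives 670 nM. Of these three numbers, that of compound 2 is the highest: the nearest to it is the number of compound 3, and the furthest is that of compound 1, and both gaps lie beyond the usual scatter of this assay.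

Compound 4 `CCCC(CCC)C(=O)OCC1(CO)C/C(=C/c2ccncc2)C(=O)O1` has not yet been measured. It differs from compound 2 in one place, (1-propylbutyl in place of 4-(dimethylamino)phenyl on a carbonyl carbon). Among the measured compounds shown here, no measured pair in this set shows that change on its own, so its effect is not known; compound 3 carries the 1-propylbutyl group but also differs from compound 2 elsewhere, so the number of compound 3, 670 nM, cannot be laid against compound 2 as a clean step. The step expected for compound 4 is therefore a modest one, toward a lower number or none beyond the scatter, and is estimated as a 1.6-fold lower number from compound 2 to compound 4 (0.20 log units; within the scatter). Compound 4 is expected to give 1500 nM in this assay, within a range of 500 nM to 5000 nM.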

Compound 4, inhibition constant: 44 nM
The estimate for compound 4 lay 34-fold (1.53 log units) above the measured number; the whole stated range lies above it.
By their numbers in this assay, from the lowest: compound 4; then compound 1; then compound 3; then compound 2.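

In this assay, among the compounds shown here, 1-propylbutyl in place of 4-(dimethylamino)phenyl on the carbonyl carbon, with pyridin-4-yl held constant, gives a 54-fold lower number from compound 2 to compound 4 (1.73 log units; beyond the scatter), the first clean reading of this position, and it shows that this exchange can change the number greatly. The other site of change matters as well: with 1-propylbutyl held constant, pyridin-4-yl in place of pyridin-3-yl gives a 15-fold lower number from compound 3 to compound 4 (1.18 log units; beyond the scatter), so the large effect of the ester group is seen alongside a large effect of the pyridine attachment. No measurement shown here accounts for either step.

As far as these compounds go, whether a straight heptyl chain or a cyclohexyl group on the same carbonyl carbon would match 1-propylbutyl remains open. Also open, from the compounds shown here alone, is whether 1-propylbutyl would bring a similar step on the core of compound 1.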